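A few compounds are considered here, and "the series" means these few. Any claim that something is new, unique, unknown or untested is made for them only; others in the source may bear on it.

Measured in a functional assay on HepG2 cells (Homo sapiens) for antiproliferative activity, read by XTT assay, with a stated time of 72 h; on this read-out higher numbers stand for weaker inhibition and lower numbers for stronger inhibition:
- compound 1 `COc1ncnc2c1c(-c1ccccc1)cn2[C@@H]1O[C@H](CO)[C@@H](O)[C@H]1O`: > 20000 nM (a limit)
- compound 2 `CNc1ncnc2c1c(-c1ccoc1)cn2[C@@H]1O[C@H](CO)[C@@H](O)[C@H]1O`: > 20000 nM (a limit)
- compound 3 `Nc1nc2c(c(-c3ccoc3)cn2[C@@H]2O[C@H](CO)[C@@H](O)[C@H]2O)c(=O)[nH]1`: > 20000 nM (a limit)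

Among the compounds with values here, the series so far shows only (the limit of > 20000 nM in this assay, at which 3 of the 3 values shown sit). Compound 3 is known only as a limit, > 20000 nM, and the expectation below rests on it.

Compound 4 `Nc1nc2c(c(-c3cc4ccccc4o3)cn2[C@@H]2O[C@H](CO)[C@@H](O)[C@H]2O)c(=O)[nH]1` carries 1-benzofuran-2-yl in place of furan-3-yl on an aromatic carbon.

Within the data shown here, the series holds no measured step between compounds that differ in one place. The expected change in this assay is a number no higher from compound 3 to compound 4 (the limit leaves the size open), none beyond the scatter in either direction.

The estimated value for compound 4 is 20000 nM, with an expected range of 8000 nM to 25000 nM.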

Compound 4, half-maximal inhibitory concentration: > 20000 nM
Compound 4 gave a limit, no number (the forecaster's own chance of this, stated with the estimate: 80%); the middle value lies on the limit itself.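

Compound 3 and compound 4 both give only a limit in this assay, so 1-benzofuran-2-yl in place of furan-3-yl yields no readable step. Whether any change to the shared core brings a value off the limit stays open: the limit of > 20000 nM in this assay, at which 4 of the 4 values shown sit.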